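Shortening the Side Chain of Compound 3

A few compounds are considered here, and "the series" means these few. Any claim that something is new, unique, unknown or untested is made for them only; others in the source may bear on it.

In a functional assay on MGC-803 cells (Homo sapiens) for inhibition, read by MTT assay, with a stated time of 48 h (a lower number here means a stronger inhibitor, a higher number a weaker inhibitor), compound 1 `C/C=C/C(=O)N(Cc1ccc(OC)c([N+](=O)[O-])c1)c1cc(OC)c(OC)c(OC)c1` gives 590 nM as its result. Compound 2 `CCCCC(=O)N(Cc1ccc(OC)c(O)c1)c1cc(OC)c(OC)c(OC)c1` gives 66 nM there and compound 3 `COCC(=O)N(Cc1ccc(OC)c(O)c1)c1cc(OC)c(OC)c(OC)c1` gives 79 nM there. Compound 3 thus sits well under compound 1 and level with compound 2 within the scatter.

Compound 4 `COc1ccc(CN(C(C)=O)c2cc(OC)c(OC)c(OC)c2)cc1O` has not been measured yet. It differs from compound 3 by a single change: hydrogen in place of methoxy on a saturated chain carbon bound to a carbonyl carbon in which hydrogen takes the place of methoxy on a saturated chain carbon bound to a carbonyl carbon. This turns (methoxymethyl)carbonyl into acetyl.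

Among the compounds with values here, only one measured step touches this same place. It is a 1.2-fold higher number from compound 2 to compound 3 (0.08 log units; within the scatter) with methoxy in place of propyl, and that is no change beyond the scatter. One small step is thin evidence, but it gives no reason to expect a large shift in this assay here. The expected result is a 1.3-fold higher number from compound 3 to compound 4 (0.10 log units; within the scatter) in a slightly higher direction at most. The estimated value for compound 4 is 100 nM within an expected range of 35 nM to 280 nM for a single measurement.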

Compound 4, half-maximal inhibitory concentration: 79 nM
Compound 4: the middle estimate sits 1.3-fold (0.10 log units) above what was measured; low and high end bracket the measured number.
By their numbers in this assay, from the lowest: compounds 2, 3 and 4 (each within the scatter of the next); then compound 1.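

The step of no change at the digits printed from compound 3 to compound 4 (within the scatter) in this assay shows that the methoxy of compound 3 can be replaced by plain hydrogen on this saturated chain carbon bound to the carbonyl carbon, leaving acetyl, with no shift beyond the scatter. The step of a 1.2-fold higher number from compound 2 to compound 4 (0.08 log units; within the scatter) extends this to propyl, so the earlier comparison of methoxy with propyl now gains a third case, and at this place none of the three groups stands apart from the others in this assay. Nothing measured on hand explains this flat result.

Still open, from the compounds shown here alone, is whether this tolerance holds for a very different group on this carbon, such as an amine, a carboxylic acid or a phenyl ring. Compound 1 differs from the others in more than one place and says nothing about this position.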